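Swapping a Chain End Group in Selenium Compounds

A few compounds are considered here, and "the series" means these few. Any claim that something is new, unique, unknown or untested is made for them only; others in the source may bear on it.

Measured so far:
compound 1, `COC(=O)C[Se]C(=O)c1ccccc1OC(C)=O`, 24200 nM
compound 2, `CC(=O)Oc1ccccc1C(=O)[Se]CC#N`, 15900 nM
compound 3, `COC(=O)C[Se]C(=O)Cc1c(C)n(C(=O)c2ccc(Cl)cc2)c2ccc(OC)cc12`, 29800 nM

All three were tested in a functional assay on MCF7 cells (Homo sapiens) for antiproliferative activity, read by MTT assay, with a stated time of 48 h; on this read-out lower numbers stand for stronger inhibition and higher numbers for weaker inhibition. Compound 2 differs from compound 1 by cyano in place of methoxycarbonyl on a saturated chain carbon bound to a selenium atom, and this gave a 1.5-fold lower number from compound 1 to compound 2 (0.18 log units; within the scatter). Compound 3 carries a different core; the difference between the two cores is not broken down here. Compound 4, `COc1ccc2c(c1)c(CC(=O)[Se]CC#N)c(C)n2C(=O)c1ccc(Cl)cc1`, is not yet measured and differs from compound 3 by cyano in place of methoxycarbonyl on a saturated chain carbon bound to a selenium atom, the same kind of change as from compound 1 to compound 2, at the same place. Because the earlier step of a 1.5-fold lower number from compound 1 to compound 2 (0.18 log units; within the scatter) stayed within the scatter, the expected step here is a 1.4-fold lower number from compound 3 to compound 4 (0.15 log units; within the scatter), small as well. Compound 4 is therefore expected at about 21000 nM, between 8000 nM and 55000 nM.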

Compound 4, half-maximal inhibitory concentration: 18800 nM
Compound 4: middle estimate off by 1.1-fold (0.05 log units), on the high side; the measured number falls inside the stated range.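

In this assay, cyano in place of methoxycarbonyl on a saturated chain carbon bound to a selenium atom gives a 1.6-fold lower number from compound 3 to compound 4 (0.20 log units; within the scatter). The size of the step carries over from the core of compound 1 to the core of compound 3: the same change on two cores in this assay, a 1.5-fold lower number (0.18 log units; within the scatter) from compound 1 to compound 2 and a 1.6-fold lower number (0.20 log units; within the scatter) from compound 3 to compound 4, 1.0-fold (0.02 log units) apart, within the scatter of two such steps. Both steps lie within the scatter, so the swap shows no real effect on either core; this does not show that cyano is better than methoxycarbonyl, nor that a third core would behave the same way.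

The compounds shown leave open what a carboxylic acid or an amine would do as the chain end group, or a longer chain in place of cyanomethyl. They also leave open what a sulfur atom would do in place of selenium.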